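The source may report more compounds than this note shows. Statements on the series, on what has been measured and on what is new or still open speak of the compounds shown alone.

Of the compounds shown here, three built on one shared core have been tested in a functional assay on HeLa cells (Homo sapiens) for antiproliferative activity, read by MTT assay, with a stated time of 48 h; on this read-out lower numbers stand for stronger inhibition of growth and higher numbers for weaker inhibition of growth. Compound 1 `CCOc1cc(NC(=O)CCCCC(=O)Nc2cc(-c3ccc(C)s3)ccc2N)cc2c1OCC([N+](=O)[O-])=C2` gives 18400 nM in this assay. Compound 2 `CCOc1cc(NC(=O)CCCCCNC(=O)CCCc2ccccc2)cc2c1OCC([N+](=O)[O-])=C2` gives 6740 nM in this assay, a number lower than that of compound 1 by a gap beyond the usual scatter, so compound 1 stands as the higher of the two numbers. Among the compounds with values here, compound 3 `CCOc1cc(NC(=O)CCCCCC(=O)Nc2cc(-c3ccc(C)s3)ccc2N)cc2c1OCC([N+](=O)[O-])=C2` gives only a limit of this assay, > 20000 nM, not a number. the limit of > 20000 nM in this assay, at which 1 of the 3 values shown sits, describes that limit, and no step between two measured compounds differing in one place has been set out, so no measured step is available to compare against.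

Compound 4 `CCOc1cc(NC(=O)CCCCC(=O)Nc2ccccc2N)cc2c1OCC([N+](=O)[O-])=C2` differs from compound 1 in one place: hydrogen in place of 5-methylthiophen-2-yl on an aromatic carbon. Within the data shown here, no measured step matches this change, and compound 1 already gives a high number. The expected step from compound 1 to compound 4 in this assay is a 1.2-fold higher number from compound 1 to compound 4 (0.08 log units; within the scatter), a small move toward weaker inhibition of growth, or none beyond the scatter. Compound 4 is therefore expected to give 22000 nM in this assay, within a range from 7000 nM to 70000 nM.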

Compound 4, concentration for 50% growth inhibition: 13100 nM
The estimate for compound 4 lay 1.7-fold (0.23 log units) above the measured number, and the stated range covers the measured number.
By their numbers in this assay, from the lowest: compounds 2, 4 and 1 (each within the scatter of the next, the first and the last beyond it). At a limit, above all of these: compound 3.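

In this assay, the step of a 1.4-fold lower number from compound 1 to compound 4 (0.15 log units; within the scatter) shows that taking away the whole 5-methylthiophen-2-yl ring, on the aromatic carbon para to an amino group, changes nothing that can be told from scatter. Within the data shown here, until now this position carried only that one group, so its role was unknown; here, a bare hydrogen serves equally well, and the ring is not needed for the modest growth inhibition seen with this core. One caution applies, since the series also holds a value that is a limit and not a number: the limit of > 20000 nM in this assay, at which 1 of the 4 values shown sits.

As far as these compounds go, whether a small methyl group, a fluorine atom or a plain phenyl ring at this carbon would move the number beyond the scatter stays open. So does whether hydrogen in place of 5-methylthiophen-2-yl would behave the same way on the longer chain of compound 3.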